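This account rests on a few compounds, and the source may have more. Where it says the series, first, only, none or still open, it means among the compounds named here.

In a functional assay on MDA-MB-231 cells (Homo sapiens) for antiproliferative activity, read by sulforhodamine B assay, with a stated time of 48 h (on this read-out higher numbers stand for weaker inhibition and lower numbers for stronger inhibition), compound 1 `COc1cc(OC)c2sc(-c3ccc(N/C=C\C(=O)c4ccc(OC)c([N+](=O)[O-])c4)c(C)c3)nc2c1` gives 10800 nM, compound 2 `COc1cc(C(=O)/C=C\Nc2ccc(-c3nc4cc(OC)c(OC)c(OC)c4s3)cc2)c(Br)c(OC)c1OC` gives 15600 nM and compound 3 `COc1ccc(C(=O)/C=C\Nc2ccc(-c3nc4cc(OC)c(OC)c(OC)c4s3)cc2)cc1O` gives 18100 nM. Compound 2 lies within the usual scatter of both other compounds, so these numbers do not rank it. Compound 4 `COc1cc(C(=O)/C=C\Nc2ccc(-c3nc4cc(OC)c(OC)c(OC)c4s3)cc2C)c(Br)c(OC)c1OC` differs from compound 2 in one place: methyl in place of hydrogen on an aromatic carbon, ortho to a large group and meta to a large group. For the measured compounds named here, no measured pair shows this change alone, so no step beyond the scatter is expected, in either direction. The expected step is a 1.2-fold lower number from compound 2 to compound 4 (0.08 log units; within the scatter). For compound 4 the estimated value is 13000 nM, with an expected range of 6000 nM to 28000 nM.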

Compound 4, half-maximal inhibitory concentration: 7300 nM
Compound 4: the middle estimate sits 1.8-fold (0.25 log units) above what was measured; the measured number falls inside the stated range.
By their numbers in this assay, from the lowest: compounds 4, 1, 2 and 3 (each within the scatter of the next, the first and the last beyond it).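

In this assay, for the compounds shown here, methyl in place of hydrogen on this aromatic carbon, ortho to a large group and meta to a large group, gives a 2.1-fold lower number from compound 2 to compound 4 (0.33 log units; beyond the scatter) as the first change here that can be read alone. This position therefore accepts one extra carbon without a loss of inhibition, and the modest step favours the methyl compound. No measurement available here explains the step. As far as these compounds go, whether an ethyl group, a chlorine atom or an amine at this position would go further, or reverse the step, stays open. Also open, from the compounds shown here alone, is whether the methyl would give a similar step in compounds with other substituents elsewhere.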